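Notes on two measured compounds and one pending analogue

This account rests on a few compounds, and the source may have more. Where it says the series, first, only, none or still open, it means among the compounds named here.

Measured so far, in a functional assay on MCF7 cells (Homo sapiens) for cytotoxicity, read by sulforhodamine B assay, with a stated time of 48 h; on this read-out higher numbers stand for weaker inhibition of growth and lower numbers for stronger inhibition of growth:
compound 1 `O=C1C(=O)N(CN(c2ccccc2)c2ccccc2)c2cccc(Cl)c21` gives 29700 nM
compound 2 `CN(C)CN1C(=O)C(=O)c2c(Br)cccc21` gives 57600 nM

Both compounds are weak growth inhibitors in this assay. Compound 2 and compound 1 lie within the usual scatter of each other, so no order between them can be read from these two values; compound 2 is simply the second of two weak growth inhibitors.

The next compound, compound 3 `CCN(CC)CN1C(=O)C(=O)c2c(Br)cccc21`, has not been measured in this assay. It differs from compound 2 in one place: diethylamino in place of dimethylamino on a saturated chain carbon bound to an amide-type nitrogen in a ring. Among the compounds with values here, no step between measured compounds covers a change of this kind, so there is nothing to calibrate it. The change is small and keeps the same atom types at the same place, so the expectation is a step of a 1.2-fold lower number from compound 2 to compound 3 (0.06 log units; within the scatter), that is, none beyond the scatter. Compound 3 is therefore expected to give about 50000 nM in this assay, with a range from 20000 nM to 125000 nM.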

Compound 3, concentration for 50% growth inhibition: 20200 nM
Estimate against measurement, compound 3: 2.5-fold (0.39 log units) above; low and high end bracket the measured number.
By their numbers in this assay, from the lowest: compounds 3, 1 and 2 (each within the scatter of the next, the first and the last beyond it).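

Working from this assay, the place on a saturated chain carbon bound to an amide-type nitrogen in a ring responds to a small change in the amine: diethylamino in place of dimethylamino gives a 2.9-fold lower number from compound 2 to compound 3 (0.46 log units; beyond the scatter) and this modest step is the first in the series that can be read at this place. Compound 1 and compound 2 could not show this: they differ in more than one place, and their values lie within the scatter of each other. No measurement on hand accounts for the step, which stands as an observation on this single pair.

On these data alone, whether the step continues with a longer chain such as dipropylamino, or holds for a ring amine such as piperidine or morpholine at the same place, remains open. Also open is the role of the halogen on the shared core, with no pair shown changing it alone.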